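The compounds below may be only part of what the source reports. "The series", "measured", "known", "first", "only" and "open" are said of these compounds alone.

In a functional assay on DLD-1 cells (Homo sapiens) for cytotoxicity, with a stated time of 48 h (on this read-out lower numbers stand for stronger inhibition and higher numbers for weaker inhibition), compound 1 `CC(=O)Oc1ccc2oc(/C=C/[S+](C)[O-])cc(=O)c2c1` shows > 10000 nM, which is a limit of the assay and not a number. For the measured compounds named here, compound 2 `C[S+]([O-])/C=C/c1cc(=O)c2cc(F)ccc2o1` gives 7000 nM, the only actual number so far. Compound 3 `COc1ccc2oc(/C=C/[S+](C)[O-])cc(=O)c2c1` differs from compound 2 at one place, with methoxy in place of fluoro on an aromatic carbon. Going by the values given here, one measured step bears on this place, an at least 1.4-fold lower number from compound 1 to compound 2 (0.15 log units; that floor lies within the scatter), and its floor lies within the scatter. Because an at least 1.4-fold lower number from compound 1 to compound 2 (0.15 log units; that floor lies within the scatter) shows no firm change, no clear shift is expected here, and the estimated move is a 1.3-fold higher number from compound 2 to compound 3 (0.11 log units; within the scatter). For compound 3 the expected value is 9000 nM, with an estimated range from 3500 nM to 23000 nM.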

Compound 3, half-maximal inhibitory concentration: 5700 nM
The estimate for compound 3 lay 1.6-fold (0.20 log units) above the measured number; low and high end bracket the measured number.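

At this place on the aromatic ring, methoxy and fluoro cannot be told apart: the change gives a 1.2-fold lower number from compound 2 to compound 3 (0.09 log units; within the scatter). Methyl in place of acetyl on the oxygen gives an at least 1.7-fold lower number from compound 1 to compound 3 (0.24 log units; that floor lies within the scatter), so this step also shows no firm change. Compound 1 stands at a limit and not at a number: the limit of > 10000 nM in this assay, at which 1 of the 3 values shown sits.

The compounds shown leave open whether an amine or a carboxylic acid at this place would move the number beyond the scatter. They also leave open whether a longer chain on the oxygen would do so.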